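The source may report more compounds than this note shows. Statements on the series, on what has been measured and on what is new or still open speak of the compounds shown alone.

Among the compounds with values here, in a functional assay on A549 cells (Homo sapiens) for cytotoxicity, read by sulforhodamine B assay, with a stated time of 48 h (a higher number here means a weaker inhibitor, a lower number a stronger inhibitor), compound 1 `O=C(/C=C/c1ccc(Br)cc1)c1cccc(-c2cccc(F)c2)c1` gives 19800 nM and compound 2 `O=C(/C=C/c1cccc(Br)c1)c1cccc(-c2cccc(F)c2)c1` gives 9120 nM, so compound 2 holds the lower of the two numbers measured so far. The next structure, compound 3 `COc1ccccc1/C=C/C(=O)c1cccc(-c2cccc(F)c2)c1`, keeps the shared core and swaps one aryl group: 2-methoxyphenyl in place of 3-bromophenyl on a double-bonded chain carbon bound to a double-bonded chain carbon. The swap is on a double-bonded chain carbon bound to a double-bonded chain carbon, the same place that differs between the two measured compounds. Within the data shown here, only one measured step bears on it: a 2.2-fold lower number from compound 1 to compound 2 (0.34 log units; beyond the scatter), a modest change from 4-bromophenyl to 3-bromophenyl. Neither measured compound carries a 2-methoxyphenyl group, so the data give no direction for this swap. The expected result is a small change, a 1.2-fold higher number from compound 2 to compound 3 (0.08 log units; within the scatter), and no large shift is anticipated. In this assay, compound 3 is estimated at 11000 nM, with an expected range of 4500 nM to 26000 nM.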

Compound 3, half-maximal inhibitory concentration: 15500 nM
Compound 3: middle estimate off by 1.4-fold (0.15 log units), on the low side; the measured number falls inside the stated range.
By their numbers in this assay, from the lowest: compounds 2, 3 and 1 (each within the scatter of the next, the first and the last beyond it).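

In this assay, both a 1.7-fold higher number from compound 2 to compound 3 (0.23 log units; within the scatter) and a 1.3-fold lower number from compound 1 to compound 3 (0.11 log units; within the scatter) stay inside the usual scatter, so at this position 2-methoxyphenyl cannot be told apart from either bromophenyl group. The earlier compounds shown here varied only where the bromine sat on the ring, whereas this result shows that an aryl group with no bromine, carrying an oxygen and a hydrogen-bond acceptor instead, gives a number of the same order. No measurement available here offers a reason for this.

The compounds shown leave open whether 3-methoxyphenyl or 4-methoxyphenyl would separate in the way the two bromophenyl compounds do. They also leave open whether a phenyl ring bearing an amine or a carboxylic acid on this double-bonded chain carbon would move the number beyond the scatter.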